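The compounds below may be only part of what the source reports. "The series", "measured", "known", "first", "only" and "open" are said of these compounds alone.

Measured compounds:
Compound 1 `Oc1cc(C(F)(F)F)ccc1-c1nc(-c2ccccc2O)n(-c2ccc(Br)cc2)n1` gives 100% in a functional assay on PC-12 cells (Rattus norvegicus) for cytotoxicity, read by MTT assay, with stated times of 2 h and 24 h, tested at 10 uM; on this read-out lower numbers stand for a weaker effect and higher numbers for a stronger effect at the one concentration tested.
Compound 2 `COc1ccc(-n2nc(-c3ccc(C(F)(F)F)cc3O)nc2-c2ccccc2O)cc1` gives 98.9% in this assay.

On these two numbers compound 2 stands alongside compound 1 rather than apart from it: the step of a number 1.1 percentage points lower from compound 1 to compound 2 (within the scatter) is within the scatter. Compound 3 `Oc1cc(C(F)(F)F)ccc1-c1nc(-c2ccccc2O)n(-c2ccc(OC(F)(F)F)cc2)n1` differs from compound 2 by trifluoromethyl in place of methyl on an oxygen on an aromatic ring. Among the measured compounds shown here, the one measured step, a number 1.1 percentage points lower from compound 1 to compound 2 (within the scatter), touches a different group and is within the scatter, so no measured step bears directly on this change, and nothing here points away from the ceiling both measured compounds reach. Compound 3 is therefore expected to sit near compound 2, with the step of a number 1.9 percentage points lower from compound 2 to compound 3 (within the scatter) expected to stay within the scatter. The estimate for compound 3 is 97%, in a range from 86% to 100%.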

Compound 3, a percentage reported as activity, at one concentration (the size of the read-out at that concentration, not a potency): 92.5%
Compound 3: middle estimate off by 4.5 percentage points, on the high side; the measured number falls inside the stated range.
By their numbers in this assay, from the lowest: compounds 3, 2 and 1 (each within the scatter of the next).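

Swapping methyl for trifluoromethyl on this oxygen gives a number 6.4 percentage points lower from compound 2 to compound 3 (within the scatter) and is the first measured change to the methoxy group itself. Trifluoromethoxy in place of bromo gives a number 7.5 percentage points lower from compound 1 to compound 3 (within the scatter), so bromo, methoxy and trifluoromethoxy on this aromatic carbon all leave this assay at one level. No evidence on the cause of this sameness is at hand. From the compounds shown here alone, whether an amine or a carboxylic acid at this place would keep the read-out at that level stays open. So does whether a longer chain on this oxygen would.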